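The source may hold more compounds than are shown below. What is called first, only, known or untested is meant among the compounds shown, and "the series" means these compounds.

Of the compounds shown here, three built on one shared core have been read in a functional assay on HT-29 cells (Homo sapiens) for antiproliferative activity, read by MTT assay, with a stated time of 24 h; a lower number here means a stronger inhibitor, a higher number a weaker inhibitor. Compound 1 `COc1ccccc1/C=C/C(=O)c1ccc(OC)c2c1OC(C)(C)C=C2` gives only a limit, > 10000 nM. Compound 2 `COc1ccc(C(=O)/C=C/c2ccc(O)cc2)c2c1C=CC(C)(C)O2` also gives only a limit, > 10000 nM. Compound 3 `CCOc1cc(/C=C/C(=O)c2ccc(OC)c3c2OC(C)(C)C=C3)ccc1O` likewise gives only a limit, > 10000 nM, so it has no number of its own and stands at the limit of > 10000 nM in this assay, at which 3 of the 3 values shown sit.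

Compound 4 `COc1ccc(C(=O)/C=C/c2ccc(O)c(Br)c2)c2c1C=CC(C)(C)O2` departs from compound 3 by one change, bromo in place of ethoxy on an aromatic carbon, ortho to a hydroxy group: bromo in place of ethoxy on an aromatic carbon. The closest measured change is a step that the two limits leave unreadable from compound 2 to compound 3, which brought in the ethoxy that now leaves. The other is a step that the two limits leave unreadable from compound 1 to compound 2. Neither has a readable size, so together they point in no direction, and no shift beyond the scatter can be forecast in this assay. The expected change is a step that the limit leaves unreadable from compound 3 to compound 4. For compound 4 the estimated value is 12000 nM, with an expected range from 4000 nM to 30000 nM.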

Compound 4, half-maximal inhibitory concentration: > 10000 nM
Compound 4 ended at the assay's limit (the forecaster's own chance of this, stated with the estimate: 70%); the middle value is on the limit's open side.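

No step from compound 1, compound 2 or compound 3 to compound 4 can be read in this assay, since all four compounds give only a limit: the limit of > 10000 nM in this assay, at which 4 of the 4 values shown sit.

The compounds shown leave open whether any of these changes on the shared core alters antiproliferative activity, and what value any of the four would have.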